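Thiophen-2-yl for furan-3-yl on a nucleoside core

The source may hold more compounds than are shown below. What is called first, only, known or untested is meant among the compounds shown, and "the series" means these compounds.

Within the data shown here, compound 1 `O=c1[nH]cnc2c1c(-c1ccoc1)cn2[C@@H]1O[C@H](CO)[C@@H](O)[C@H]1O` is the only member with a numerical result in a functional assay on HCT-116 cells (Homo sapiens), read by MTT assay, with a stated time of 72 h; a higher number here means a weaker inhibitor, a lower number a stronger inhibitor; there compound 1 gives 14800 nM. Compound 2 `C#Cc1cn([C@@H]2O[C@H](CO)[C@@H](O)[C@H]2O)c2ncnc(C)c12` is reported in this assay only as > 20000 nM, which is a limit of the assay rather than a number (the limit of > 20000 nM in this assay, at which 1 of the 2 values shown sits). Among the measured compounds shown here, no step between two measured compounds is available, so nothing measured speaks for the size of the move to compound 3 `O=c1[nH]cnc2c1c(-c1cccs1)cn2[C@@H]1O[C@H](CO)[C@@H](O)[C@H]1O`, which differs from compound 1 by thiophen-2-yl in place of furan-3-yl on an aromatic carbon. With the shared core kept and one five-membered aromatic ring with 1 hetero atom exchanged for another of 5 heavy atoms, the step in this assay is expected to be small, at or near the scatter, if anything toward a stronger inhibitor. Compound 3 is therefore estimated at 10000 nM, within 2500 nM to 25000 nM. For compound 3 the expected step is a 1.5-fold lower number from compound 1 to compound 3 (0.17 log units; within the scatter).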

Compound 3, half-maximal inhibitory concentration: > 20000 nM
Compound 3 gave a limit, no number; the forecaster's own chance of this, stated with the estimate: 30%; at least 2.0-fold (0.30 log units) between middle value and limit.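

Among these compounds, this is the first direct read on this aromatic carbon of the shared core: in this assay, thiophen-2-yl in place of furan-3-yl gives an at least 1.3-fold higher number from compound 1 to compound 3 (0.13 log units; that floor lies within the scatter). Compound 3 gives > 20000 nM, which is a limit of the assay and not a number: the limit of > 20000 nM in this assay, at which 2 of the 3 values shown sit. Exchanging one five-membered aromatic ring with 1 hetero atom for another therefore brings no gain at this position, although the floor of the step does not establish a real loss.

From the compounds shown here alone, how far compound 3 lies beyond its limit stays unknown, so the true size of the step cannot be read. Also open, going by these compounds, is how this assay responds at this carbon to a group of another kind, such as a phenyl ring, an amine or a carboxylic acid.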